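Swapping chloro for bromo on a pyridine ring

The source may report more compounds than this note shows. Statements on the series, on what has been measured and on what is new or still open speak of the compounds shown alone.

Measured compounds:
compound 1, `O=C(CSc1nnc(NC(=O)CCl)s1)Nc1ccc(Cl)cn1`: 8600 nM
compound 2, `O=C(CSc1nnc(NC(=O)CCl)s1)Nc1ccc(Br)cn1`: 13900 nM
compound 3, `O=C(CCl)Nc1ccc(SCC(=O)Nc2ccc(Cl)cn2)cc1`: 98 nM

All three were tested in a functional assay on A875 cells (Homo sapiens) for antiproliferative activity, read by MTT assay, with a stated time of 48 h; on this read-out higher numbers stand for weaker inhibition and lower numbers for stronger inhibition. Compound 1 and compound 2 share one core, and compound 3 has a different core; the difference between the two cores is not broken down here. What can be said is that compound 3 gives a far lower number than either of the other two, and for this read-out a lower number means stronger inhibition.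

Within the first pair, compound 2 differs from compound 1 by a single change, (bromo in place of chloro on an aromatic carbon). That change made a 1.6-fold higher number from compound 1 to compound 2 (0.21 log units; within the scatter), so on this evidence it barely moved the read-out.

Compound 4, `O=C(CCl)Nc1ccc(SCC(=O)Nc2ccc(Br)cn2)cc1`, has not yet been measured. It stands to compound 3 exactly as compound 2 stands to compound 1: the change is bromo in place of chloro on an aromatic carbon, and the surroundings of the change are the same in both pairs. Within the data shown here, only one such pair has been measured, so the expectation rests on a single observation.

Because of a 1.6-fold higher number from compound 1 to compound 2 (0.21 log units; within the scatter), the step from compound 3 to compound 4 in this assay is expected to be small, about a 1.5-fold higher number from compound 3 to compound 4 (0.18 log units; within the scatter). Compound 4 is therefore estimated at 150 nM, likely between 60 nM and 400 nM.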

Compound 4, half-maximal inhibitory concentration: 290 nM
The estimate for compound 4 lay 1.9-fold (0.29 log units) below the measured number; measured number inside the range.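

On the core of compound 3, a 3.0-fold higher number from compound 3 to compound 4 (0.47 log units; beyond the scatter) in this assay, so going from 5-chloropyridin-2-yl to 5-bromopyridin-2-yl raised the number by a modest step here. Among these compounds, although only this step lies beyond the scatter, the two steps cannot be told apart, so the change carried from one core to the other with a similar size: the same change on two cores in this assay, a 1.6-fold higher number (0.21 log units; within the scatter) from compound 1 to compound 2 and a 3.0-fold higher number (0.47 log units; beyond the scatter) from compound 3 to compound 4, 1.8-fold (0.26 log units) apart, within the scatter of two such steps. This rests on just two pairs, so it does not show that the change would behave the same way on a third core, and it gives no reason for the size of either step.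

The compounds shown leave open how a fluoro group, a methyl group or an amine would read in this assay on the same aromatic carbon, where only chloro and bromo appear. They also leave open what would happen if the chlorine of the chloroacetyl group were replaced by hydrogen, since every compound here carries that chlorine.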